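Adding a methoxy to the phenyl of compound 1

This account rests on a few compounds, and the source may have more. Where it says the series, first, only, none or still open, it means among the compounds named here.

Three compounds have been measured in a functional assay on MDA-MB-435 cells (Homo sapiens) for inhibition; a lower number here means a stronger inhibitor of growth, a higher number a weaker inhibitor of growth:

Compound 1, `COc1cc(/C=C/C(=O)c2cccc(-n3cc(-c4ccccc4)[nH]c3=O)c2)ccc1O`: 2140 nM
Compound 2, `O=C(/C=C/c1cccc(O)c1)c1cccc(-n2cc(-c3ccccc3)[nH]c2=O)c1`: 3120 nM
Compound 3, `COc1cc(/C=C/C(=O)c2cccc(-n3cc(-c4ccccc4)[nH]c3=O)c2)cc(OC)c1OC`: 1200 nM

Compound 1 gives the second highest of these three numbers; its nearest neighbour is compound 2, and compound 3 stands furthest from it, though neither gap exceeds the scatter. Going by the values given here, the one step between measured compounds differing in a single place, a 1.5-fold higher number from compound 1 to compound 2 (0.16 log units; within the scatter), alters the aryl on the double-bonded chain and stays within the scatter. Compound 4, `COc1ccc(-c2cn(-c3cccc(C(=O)/C=C/c4ccc(O)c(OC)c4)c3)c(=O)[nH]2)cc1`, differs from compound 1 elsewhere: methoxy in place of hydrogen on an aromatic carbon, so that the phenyl on the core becomes 4-methoxyphenyl. Among the compounds with values here, no measured pair alters this part of the structure, and the only measured step, on the other ring, is itself within the scatter, so there is no basis for expecting a step in this assay beyond the scatter in either direction. Compound 4 is therefore expected to give about 2000 nM, within a range of 900 nM to 4500 nM. The step this estimate implies, a 1.1-fold lower number from compound 1 to compound 4 (0.03 log units; within the scatter), is expected to lie within the scatter.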

Compound 4, concentration for 50% growth inhibition: 3350 nM
Compound 4: middle estimate off by 1.7-fold (0.22 log units), on the low side; low and high end bracket the measured number.
By their numbers in this assay, from the lowest: compounds 3, 1, 2 and 4 (each within the scatter of the next, the first and the last beyond it).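

In this assay, methoxy in place of hydrogen on an aromatic carbon, para to a large group, gives a 1.6-fold higher number from compound 1 to compound 4 (0.19 log units; within the scatter). Going by these compounds alone, this is the first measured change at the phenyl on the core, and it shows that this position accepts the 4-methoxyphenyl without a step beyond the scatter, just as the change at the other aryl, a 1.5-fold higher number from compound 1 to compound 2 (0.16 log units; within the scatter), stayed within it. No independent measurement is available to explain this result.

Going by these compounds, one group at one place says little about the position as a whole, so it remains open whether an amine, a carboxylic acid or a chlorine there would produce a step beyond the scatter. Also open, on these data alone, is whether the same change from phenyl to 4-methoxyphenyl would give a similar result on compound 3.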